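Dichlorobenzyl to fluorobenzyl on a diamino core

A few compounds are considered here, and "the series" means these few. Any claim that something is new, unique, unknown or untested is made for them only; others in the source may bear on it.

Within the data shown here, compound 1 `Nc1cc(N)c2nc(-c3ccccc3)c(NCc3ccc(Cl)c(Cl)c3)nc2c1` is the only compound of this set with a number of its own: in a functional assay on PC-3 cells (Homo sapiens) for inhibition, read by sulforhodamine B assay, with a stated time of 48 h (a higher number here means a weaker inhibitor of growth, a lower number a stronger inhibitor of growth), compound 1 gives 5130 nM. Compound 2 `CCOC(=O)[C@H](CCC(=O)O)NC(=O)c1ccc(Sc2nc3cc(N)cc(N)c3nc2-c2ccccc2)cc1` carries a thioether-linked amide of a glutamate ester in place of the benzylamine, and in this assay compound 2 reaches only a limit, < 100000 nM, which is the limit of < 100000 nM in this assay, at which 1 of the 3 values shown sits. Compound 3 `CCOC(=O)[C@H](CCC(=O)O)NC(=O)c1ccc(Oc2nc3cc(N)cc(N)c3nc2-c2ccccc2)cc1` holds the same side chain through an ether link, and in this assay compound 3 also stops at a limit, < 50200 nM, which is the limit of < 50200 nM in this assay, at which 1 of the 3 values shown sits. Neither limit is a number, so no step can be read from them.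

Compound 4 `Nc1cc(N)c2nc(-c3ccccc3)c(NCc3ccc(F)cc3)nc2c1` differs from compound 1 in one place: 4-fluorophenyl in place of 3,4-dichlorophenyl on a saturated chain carbon bound to a nitrogen on an aromatic ring. Among the measured compounds shown here, no measured pair shows this exchange, so the size of the step rests on judgement alone. A small loss, somewhat beyond the scatter, is expected from compound 1 to compound 4, a 2.1-fold higher number from compound 1 to compound 4 (0.33 log units; beyond the scatter). In this assay compound 4 is therefore expected to give about 11000 nM, with a plausible range from 3500 nM to 35000 nM.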

Compound 4, concentration for total growth inhibition: 15500 nM
The estimate for compound 4 lay 1.4-fold (0.15 log units) below the measured number, within the range that was stated.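

Among these compounds, at the place on a saturated chain carbon bound to a nitrogen on an aromatic ring, this assay now gives the first readable step of this set: a 3.0-fold higher number from compound 1 to compound 4 (0.48 log units; beyond the scatter). The ring itself stays a six-membered aromatic ring of carbon only, so the number is shown to respond to the halogens it carries, which the earlier compounds could not show. Nothing measured here bears on why the number moves.

As far as these compounds go, one exchange both removes the two chlorines and adds a fluorine, so what each contributes stays open, and a 4-chlorobenzyl or an unsubstituted benzyl group would separate them. Among the compounds shown here, the values of compound 2 and compound 3 are limits, so no steps involving them can be read.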